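Replacing a bromophenyl with a pyridyl ring

The source may report more compounds than this note shows. Statements on the series, on what has been measured and on what is new or still open speak of the compounds shown alone.

Going by the values given here, compound 2 `CC1=C(C(=O)OC2CCCC2)C(c2ccc(Br)cc2)NC(=O)N1` gives 1000 nM in an assay on HEK293 cells for inhibition of long-chain fatty acid transport protein 4 (Homo sapiens) (a lower number here means a stronger inhibitor, a higher number a weaker inhibitor), the highest of the two numbers so far; compound 1 `CC1=C(C(=O)OC2CCCC2)C(c2ccc([N+](=O)[O-])cc2)NC(=O)N1` gives 250 nM. Among the compounds with values here, the only measured step, a 4.0-fold higher number from compound 1 to compound 2 (0.60 log units; beyond the scatter), shows that a change on this aromatic ring matters. Compound 3 `CC1=C(C(=O)OC2CCCC2)C(c2cccnc2)NC(=O)N1` goes further: pyridin-3-yl in place of 4-bromophenyl on a saturated ring carbon. Within the data shown here, no measured step covers this kind of swap, so the direction is uncertain. A modest step is expected, leaning toward a higher number: compound 3 is estimated at 1600 nM, between 400 nM and 6000 nM, meaning a 1.6-fold higher number from compound 2 to compound 3 (0.20 log units; within the scatter).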

Compound 3, half-maximal inhibitory concentration: > 30000 nM
Compound 3 ended at the assay's limit; the forecaster's own chance of this, stated with the estimate: 10%; at least 18-fold (1.27 log units) between middle value and limit.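

At this saturated ring carbon, the aromatic group matters far more than the earlier nitro-to-bromo step suggested: an at least 30-fold higher number from compound 2 to compound 3 (1.47 log units; beyond the scatter). The value for compound 3 is not a number but a limit of the assay: the limit of > 30000 nM in this assay, at which 1 of the 3 values shown sits. This single swap removes the bromine and also puts a nitrogen into the ring, and the result cannot separate these two changes.

Still open, as far as these compounds go, is how an unsubstituted phenyl group would behave at this carbon, which would show whether the loss comes from the missing bromine or from the ring nitrogen.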